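This account rests on a few compounds, and the source may have more. Where it says the series, first, only, none or still open, it means among the compounds named here.

Measured compounds:
- compound 1, `COc1cccc(-c2cc(C(=O)Nc3ccc(Oc4ccnc5cc(OCCCN6CCCCC6)c(OC)cc45)c(F)c3)c3ccccc3n2)c1` — in a functional assay on HT-29 cells (Homo sapiens) for cytotoxicity, read by MTT assay, with a stated time of 72 h (a higher number here means a weaker inhibitor, a lower number a stronger inhibitor), compound 1 gives 1740 nM
- compound 2, `COc1cccc(-c2cc(C(=O)Nc3ccc(Oc4ccnc5cc(OCCCN6CCCC6)c(OC)cc45)c(F)c3)c3ccccc3n2)c1` — in this assay compound 2 gives 1020 nM
- compound 3, `COc1cc2c(Oc3ccc(NC(=O)c4cc(-c5ccccc5)nc5ccc(F)cc45)cc3F)ccnc2cc1OCCCN1CCCCC1` — in this assay compound 3 gives 120 nM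

Compound 1 and compound 2 share one core, and compound 3 sits on a different core; the difference between the two cores is not broken down here. Of the three numbers, compound 3 has the lowest, and its distance to compound 2 and to compound 1 lies beyond the scatter, so compound 3 is the strongest of the measured set.

Between compound 1 and compound 2 one change was made: pyrrolidin-1-yl in place of piperidin-1-yl on a saturated chain carbon, three bonds along the chain from an oxygen on an aromatic ring The step it produced is a 1.7-fold lower number from compound 1 to compound 2 (0.23 log units; within the scatter), a change small enough to count as noise in repeated measurements.

Compound 4, `COc1cc2c(Oc3ccc(NC(=O)c4cc(-c5ccccc5)nc5ccc(F)cc45)cc3F)ccnc2cc1OCCCN1CCCC1`, is not yet measured. It stands to compound 3 as compound 2 stands to compound 1, with the same change made at the same place: pyrrolidin-1-yl in place of piperidin-1-yl on a saturated chain carbon, three bonds along the chain from an oxygen on an aromatic ring Since the place is worded the same for both pairs, this is the same change, only made on the other core.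

Among the compounds with values here, the one measured example of this change, the step from compound 1 to compound 2 in this assay, stayed within the scatter, so compound 4 is expected to stay close to compound 3, and the expected step is a 1.3-fold lower number from compound 3 to compound 4 (0.12 log units; within the scatter). This expectation rests on a single measured pair on a different core, so it is held loosely. For compound 4 in this assay the estimated value is 90 nM, expected to fall between 40 nM and 250 nM.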

Compound 4, half-maximal inhibitory concentration: 160 nM
Compound 4: middle estimate off by 1.8-fold (0.25 log units), on the low side; the range from low to high includes it.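

In this assay the swap of piperidin-1-yl for pyrrolidin-1-yl on the core of compound 3 gives a 1.3-fold higher number from compound 3 to compound 4 (0.12 log units; within the scatter) and so leaves no readable mark, as it did on the core of compound 1. Set side by side, the two steps cannot be told apart, even though their printed directions are opposite: the same change on two cores in this assay, a 1.7-fold lower number (0.23 log units; within the scatter) from compound 1 to compound 2 and a 1.3-fold higher number (0.12 log units; within the scatter) from compound 3 to compound 4, 2.3-fold (0.36 log units) apart, within the scatter of two such steps. This shows that, on these two cores and in this one assay, the change carries over as a step too small to read, but it does not show that the two rings are equivalent in general, since two small steps cannot reveal a real effect hidden within the scatter, and two cores say nothing about any third core.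

The compounds shown leave open what happens when the ring at the end of the chain is replaced by a different amine, such as a morpholine, a piperazine or an open-chain dimethylamine. They also leave open whether a shorter or longer chain in place of the 3-(piperidin-1-yl)propyl group would keep the two rings as hard to separate as they are here.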